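A 3,4-difluorophenyl in place of 2,4-difluorophenyl

The compounds below may be only part of what the source reports. "The series", "measured", "known", "first", "only" and "open" are said of these compounds alone.

In an ADME assay on LLC-MK2 cells (Macaca mulatta) for cytotoxicity, read by spectrophotometry and crystal violet staining, with a stated time of 4 days (on this read-out lower numbers stand for higher toxicity in this test and higher numbers for lower toxicity in this test), compound 1 `CC(C)n1ncc2c(C(=O)Nc3cccc(C(N)=O)c3)cc(-c3cccs3)nc21` gives 25000 nM. Compound 2 `CC(C)n1ncc2c(C(=O)Nc3ccc(F)cc3F)cc(-c3cccs3)nc21` gives > 200000 nM, which is a limit of the assay and not a number. For the measured compounds named here, the only measured step, an at least 8.0-fold higher number from compound 1 to compound 2 (0.90 log units; beyond the scatter), puts 2,4-difluorophenyl in place of 3-carbamoylphenyl on an amide-type nitrogen. That step ends at a limit, so its full size is not known.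

Compound 3 `CC(C)n1ncc2c(C(=O)Nc3ccc(F)c(F)c3)cc(-c3cccs3)nc21` has 3,4-difluorophenyl in place of 2,4-difluorophenyl on the same amide-type nitrogen (3,4-difluorophenyl in place of 2,4-difluorophenyl on an amide-type nitrogen). The two compounds have the same atoms, joined differently. No exchange between two difluorophenyl groups has been measured, so the evidence is indirect. Compound 3 keeps a difluorophenyl and lacks the 3-carbamoylphenyl of compound 1, and the one measured rise, an at least 8.0-fold higher number from compound 1 to compound 2 (0.90 log units; beyond the scatter), came with the loss of that group. No step beyond the scatter is therefore expected, and the number should stay high in this assay. The expected change is small, as an at least 1.2-fold lower number from compound 2 to compound 3 (0.09 log units; that floor lies within the scatter). Compound 3 is estimated at 160000 nM, with an expected range from 60000 nM to 250000 nM.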

Compound 3, half-maximal cytotoxic concentration: > 200000 nM
Compound 3: a limit, no number; the forecaster's own chance of this, stated with the estimate: 55%; at least 1.2-fold (0.09 log units) between middle value and limit.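

The 3,4-difluorophenyl on the amide-type nitrogen gives the same kind of result as the 2,4-difluorophenyl: in this assay, its exchange for 3-carbamoylphenyl gives an at least 8.0-fold higher number from compound 1 to compound 3 (0.90 log units; beyond the scatter), and this step also ends at a limit of the assay, so its full size is not known. The high reading is therefore not tied to a single difluorophenyl group, since compound 2 and compound 3 both end at the limit, while compound 1, with its 3-carbamoylphenyl, gives a number. The exchange between the two difluorophenyl groups cannot be read, because both compounds stop at the same limit: the limit of > 200000 nM in this assay, at which 2 of the 3 values shown sit.

The compounds shown leave open whether the lower number of compound 1 goes with its carbamoyl group or with the lack of fluorine, a question that a plain phenyl or a carboxylic acid in place of the carbamoyl group on the same phenyl ring would address. Also open, going by these compounds, are how far compound 2 and compound 3 lie past the limit and whether an amine on the phenyl ring would bring the number down, as in compound 1.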